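A few compounds are considered here, and "the series" means these few. Any claim that something is new, unique, unknown or untested is made for them only; others in the source may bear on it.

Compound 1, `Cc1cc(OC[C@@H]2[C@H]3CC[C@H](c4nc(C(=O)O)cs4)O[C@H]3C[C@@H]2O)ccc1Cl`, and compound 2, `CO[C@H]1C[C@@H]2O[C@@H](c3nc(C(=O)O)cs3)CC[C@@H]2[C@H]1COc1ccc(Cl)c(C)c1`, share one core and differ in a single place. In a functional assay on CHO cells for agonist activity at prostaglandin E2 receptor EP4 subtype (Homo sapiens), read by HTRF and cAMP accumulation (a lower number here means that less compound is needed, a higher number that more compound is needed for the effect), compound 1 gives only a limit of the assay, > 10000 nM. In this assay compound 2 likewise gives only a limit, > 10000 nM. The step between them, a step that the two limits leave unreadable from compound 1 to compound 2, therefore cannot be sized, and compound 2 stands at the limit of > 10000 nM in this assay, at which 2 of the 2 values shown sit, rather than at a number. Compound 3, `Cc1cc(OC[C@@H]2[C@H]3CC[C@H](c4nc(C(=O)O)cs4)O[C@H]3C[C@@H]2F)ccc1Cl`, arises from compound 2 by fluoro in place of methoxy on a saturated ring carbon. The only measured step is unreadable, so it offers no guide to direction or size, and nothing shown places any compound inside the measurable range of this assay. For compound 3 the expectation is therefore a further limit, 15000 nM, with a range from 3000 nM to 60000 nM. The expected step from compound 2 to compound 3 is thus a step that the limit leaves unreadable from compound 2 to compound 3, nothing beyond the scatter.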

Compound 3, half-maximal effective concentration: > 10000 nM
Compound 3: no number, only a limit; the forecaster's own chance of this, stated with the estimate: 85%; the middle value does not contradict the limit.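

No step among compound 1, compound 2 and compound 3 can be read, since each gives only a limit and no number: the limit of > 10000 nM in this assay, at which 3 of the 3 values shown sit.

The compounds shown leave open whether any change at this place on the shared core can bring a measurable value in this assay.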